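A few compounds are considered here, and "the series" means these few. Any claim that something is new, unique, unknown or untested is made for them only; others in the source may bear on it.

Measured compounds in the series:

- compound 1 `COc1ccc(N(C(=O)CN2C=CN(c3cccnc3)C(=O)C(Cc3n[nH]c4cc(F)ccc34)C2=O)C(C)C)cc1`: 661 nM
- compound 2 `COc1ccc(N(C(=O)CN2C=CN(c3cccnc3)C(=O)C(Cc3n[nH]c4ccccc34)C2=O)C(C)C)cc1`: 2880 nM
- compound 3 `O=C1C(Cc2n[nH]c3cc(F)ccc23)C(=O)N(c2ccccc2)C=CN1CC(=O)N1CCCCc2ccccc21`: 437 nM

All three were tested in a functional assay on CHO cells for agonist activity at Melanocortin receptor 4 (Homo sapiens), read by a luciferase reporter, with a stated time of 4 h; a higher number here means that more compound is needed for the effect, a lower number that less compound is needed. Compound 1 and compound 2 share one core and differ in a single place: hydrogen in place of fluoro on an aromatic carbon. This change gave a 4.4-fold higher number from compound 1 to compound 2 (0.64 log units; beyond the scatter).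

Compound 3 carries a different core. How the core of compound 3 differs from the core of compound 1 is not broken down here. In this assay compound 3 gives 437 nM, which lies within the scatter of the value of compound 1, so no order between these two is claimed; compound 2 sits beyond the scatter from both.

Compound 4 `O=C1C(Cc2n[nH]c3ccccc23)C(=O)N(c2ccccc2)C=CN1CC(=O)N1CCCCc2ccccc21` is not yet measured. It stands to compound 3 as compound 2 stands to compound 1: hydrogen in place of fluoro on an aromatic carbon. The place is described in the same words for both pairs, so this is the same change, seen here for the second time among the compounds shown.

Going by the values given here, the only guide for compound 4 is the one earlier instance, which rests on a single pair and may not carry over to the other core. It is nevertheless expected that the step from compound 3 to compound 4 in this assay will resemble the earlier one, roughly a 4.3-fold higher number from compound 3 to compound 4 (0.64 log units; beyond the scatter), because the change is the same as in a 4.4-fold higher number from compound 1 to compound 2 (0.64 log units; beyond the scatter). On that basis compound 4 is estimated at 1900 nM, with a likely range from 700 nM to 5500 nM.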

Compound 4, half-maximal effective concentration: 324 nM
For compound 4 the middle estimate is 5.9-fold (0.77 log units) above the measured one; the measured number lies below the stated range.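

In this assay, hydrogen in place of fluoro on the aromatic carbon gives a 1.3-fold lower number from compound 3 to compound 4 (0.13 log units; within the scatter) on the core of compound 3, against a 4.4-fold higher number from compound 1 to compound 2 (0.64 log units; beyond the scatter) on the core of compound 1. Each core is represented by a single pair, so this shows only that the effect seen on one core cannot be assumed on the other; it does not show which feature of the cores accounts for the contrast, or how the change would behave on a further core. The two steps do differ, so a single transfer value for this change does not hold across the two cores shown: the same change on two cores in this assay, a 4.4-fold higher number (0.64 log units; beyond the scatter) from compound 1 to compound 2 and a 1.3-fold lower number (0.13 log units; within the scatter) from compound 3 to compound 4, 5.9-fold (0.77 log units) apart, beyond the scatter of two such steps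

As far as these compounds go, it remains open whether other groups on the same aromatic carbon, such as chloro, nitrile or an amine, would also give steps that differ between the two cores, or whether this contrast is particular to fluoro and hydrogen. Also open, from the compounds shown here alone, is how the change would behave on intermediate compounds that carry only part of the difference between the two cores, which would help to locate the part of the core that governs the size of the step.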